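Moving the Fluorine Within the Shared Core

A few compounds are considered here, and "the series" means these few. Any claim that something is new, unique, unknown or untested is made for them only; others in the source may bear on it.

Compound 1 `Oc1ccccc1-c1cc(-c2ccccc2F)cc(-c2ccccc2O)n1` gives > 50000 nM in a functional assay on HeLa cells (Homo sapiens) for inhibition (a lower number here means a stronger inhibitor, a higher number a weaker inhibitor), a limit of the assay rather than a number.
Compound 2 `Oc1ccccc1-c1cc(-c2cccc(F)c2)cc(-c2ccccc2O)n1` gives > 50000 nM in this assay, again a limit.
Compound 3 `Oc1cccc(-c2cc(-c3ccccc3F)cc(-c3ccccc3O)n2)c1` gives 31100 nM in this assay.

Among the compounds with values here, compound 3 is the only compound with a measured number; the other two sit at the limit of > 50000 nM in this assay, at which 2 of the 3 values shown sit. The step of an at least 1.6-fold lower number from compound 1 to compound 3 (0.20 log units; that floor lies within the scatter) swaps a 2-hydroxyphenyl for a 3-hydroxyphenyl, and its size only reaches the edge of the scatter.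

Compound 4 `Oc1cccc(-c2cc(-c3cccc(F)c3)cc(-c3ccccc3O)n2)c1` is the unmeasured compound. It differs from compound 3 by 3-fluorophenyl in place of 2-fluorophenyl on an aromatic carbon. The same exchange has been measured once, as a step that the two limits leave unreadable from compound 1 to compound 2, and that step is left unreadable by the two limits. Within the data shown here, no measured step therefore points in either direction for this change, and no step beyond the scatter is expected from it.

Compound 4 is expected to give 35000 nM, with a range from 12000 nM to 90000 nM. This amounts to an expected step of a 1.1-fold higher number from compound 3 to compound 4 (0.05 log units; within the scatter), which is within the scatter.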

Compound 4, half-maximal inhibitory concentration: > 50000 nM
Compound 4: no number, only a limit; the forecaster's own chance of this, stated with the estimate: 40%; middle value at least 1.4-fold (0.15 log units) from the limit.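

Compared with the earlier pair, where two limits hid the same exchange, 3-fluorophenyl in place of 2-fluorophenyl now gives a readable floor in this assay: an at least 1.6-fold higher number from compound 3 to compound 4 (0.20 log units; that floor lies within the scatter). Within the data shown here, that floor stays within the scatter, so it shows no real loss, although the one measured number in the set does not survive this change and the new compound ends at the limit of the assay: the limit of > 50000 nM in this assay, at which 3 of the 4 values shown sit. The step from compound 2 to compound 4 joins two limits and cannot be read.

The true size of the fluorine move stays hidden behind the limit of compound 4. Also open, from the compounds shown here alone, is whether an amine or a carboxylic acid in place of the fluorine would shift compound 3 from its 31100 nM by more than the scatter.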